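The source may hold more compounds than are shown below. What is called first, only, known or untested is meant among the compounds shown, and "the series" means these compounds.

Compound 1 `COc1ccc(-c2cc(NC(=O)Nc3ccncc3)cc(C(F)(F)F)c2)cn1` gives 276000 nM in a functional assay on A549 cells (Homo sapiens) for inhibition, read by MTT assay, with a stated time of 48 h; a lower number here means a stronger inhibitor, a higher number a weaker inhibitor. Compound 2 `O=C(Nc1ccncc1)Nc1cc(-c2cncnc2)cc(C(F)(F)F)c1` gives 2420 nM in this assay, and the change pyrimidin-5-yl in place of 6-methoxypyridin-3-yl on an aromatic carbon brings a 110-fold lower number from compound 1 to compound 2 (2.06 log units; beyond the scatter). Compound 3 `COc1ccc(-c2ccc(OC(F)(F)F)c(NC(=O)Nc3ccncc3)c2)cn1` reaches only a limit in this assay, > 300000 nM, which is the limit of > 300000 nM in this assay, at which 1 of the 3 values shown sits. How the core of compound 3 differs from that of compound 1 is not broken down here. Compound 4 `O=C(Nc1ccncc1)Nc1cc(-c2cncnc2)ccc1OC(F)(F)F` has not yet been measured; it differs from compound 3 by pyrimidin-5-yl in place of 6-methoxypyridin-3-yl on an aromatic carbon, the same kind of change as that from compound 1 to compound 2, though here the place is para to a trifluoromethoxy group rather than meta to a trifluoromethyl group. A step of similar size is expected, an at least 15-fold lower number from compound 3 to compound 4 (1.17 log units; beyond the scatter), resting on the measured 110-fold lower number from compound 1 to compound 2 (2.06 log units; beyond the scatter), with wide uncertainty as compound 3 gave only a limit. Compound 4 is estimated at 20000 nM, expected between 3000 nM and 300000 nM.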

Compound 4, half-maximal inhibitory concentration: 3750 nM
Estimate against measurement, compound 4: 5.3-fold (0.73 log units) above, and the stated range covers the measured number.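

The change from 6-methoxypyridin-3-yl to pyrimidin-5-yl brings an at least 80-fold lower number from compound 3 to compound 4 (1.90 log units; beyond the scatter) in this assay on this second core, so on both cores shown the change goes in the same direction and the step is large: the same change on two cores in this assay, a 110-fold lower number (2.06 log units; beyond the scatter) from compound 1 to compound 2 and an at least 80-fold lower number (1.90 log units; beyond the scatter) from compound 3 to compound 4; the limit leaves it open whether they differ. On these data alone, compound 3 gives > 300000 nM as a limit of the assay and not a number, so the exact size of the step on its core stays unknown: the limit of > 300000 nM in this assay, at which 1 of the 4 values shown sits. These two pairs show that the change carried over between these two cores, but they do not show that it would carry over to any other core.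

The compounds shown leave open what a core with a nitrile or a methyl group in place of trifluoromethyl or trifluoromethoxy would give. They also leave open how an amine or a carboxylic acid on the added ring would compare with pyrimidin-5-yl.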